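From methoxycarbonyl to carboxy: a solubility step ahead

The source may report more compounds than this note shows. Statements on the series, on what has been measured and on what is new or still open speak of the compounds shown alone.

Measured so far:
- compound 1 (`CN1CCc2nc(C(=O)NC3CN(S(C)(=O)=O)CCC3NC(=O)c3cc4cc(Cl)ccc4[nH]3)sc2C1`) with 103 ug/mL in the test described below
- compound 2 (`COC(=O)CN1CC[C@H](NC(=O)c2cc3cc(Cl)ccc3[nH]2)[C@H](NC(=O)c2nc3c(s2)CN(C)CC3)C1`) with 28 ug/mL in the same test

In a physicochemical assay for solubility, at pH 6.8 (a higher number here means a more soluble compound, a lower number a less soluble compound), compound 2 gives 28 ug/mL and so stands lowest of the two measured compounds. Its nearest neighbour is compound 1 at 103 ug/mL on this scale, and the gap between them lies beyond the usual scatter.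

The next compound, compound 3 (`CN1CCc2nc(C(=O)N[C@@H]3CN(CC(=O)O)CC[C@@H]3NC(=O)c3cc4cc(Cl)ccc4[nH]3)sc2C1`), still awaits its measurement in this assay and departs from compound 2 in a single place (hydrogen in place of methyl on an oxygen next to a carbonyl group). It carries hydrogen in place of methyl on an oxygen next to a carbonyl group. The same difference, read further out, is methoxycarbonyl to carboxy, or (methoxycarbonyl)methyl to carboxymethyl.

For the measured compounds named here, no pair of measured compounds shows this change, so the data offer no direct size for it, and the expectation is a judgement with wide margins. An upward step beyond the scatter is expected (a 5.4-fold higher number from compound 2 to compound 3 (0.73 log units; beyond the scatter)). The estimated value for compound 3 is 150 ug/mL (expected range from 50 ug/mL to 500 ug/mL).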

Compound 3, solubility: 723 ug/mL
Estimate against measurement, compound 3: 4.8-fold (0.68 log units) below; measured number outside the range, above it.
By their numbers in this assay, from the lowest: compound 2; then compound 1; then compound 3.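

With compound 3, this assay gains its first pair of compounds that differ in one place, so the change at this position now has a measured size: hydrogen in place of methyl on an oxygen next to a carbonyl group comes with a 26-fold higher number from compound 2 to compound 3 (1.41 log units; beyond the scatter) in this series. Compound 1 and compound 2 differ in more than one place and could give no such reading, whereas this step is large and shows that the end of the (methoxycarbonyl)methyl chain is a position at which a change of a single methyl is accompanied by a wide shift in the read-out. No measurement among the data given explains the size of this step.

One pair cannot tell whether a step of this size belongs to the carboxymethyl group alone or would also appear with a primary amide, a tetrazole or an amine at this place. It also leaves open whether a longer chain, such as carboxyethyl, would behave like carboxymethyl, and whether the same change would read alike on a different core.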